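Swapping the Amide Ring Partner in a Fatty Acid Receptor Agonist

The source may report more compounds than this note shows. Statements on the series, on what has been measured and on what is new or still open speak of the compounds shown alone.

Compound 1 `CC(C)C(c1ccc(Cl)cc1)S(=O)(=O)Nc1nccs1` in a functional assay on CHO cells for agonist activity at Free fatty acid receptor 2 (Homo sapiens), read by cAMP accumulation (on this read-out lower numbers stand for smaller maximal responses and higher numbers for larger maximal responses), gives < 30%, which is a limit of the assay rather than a number. Among the compounds with values here, compound 2 `CC(C)[C@H](C(=O)Nc1ccc(F)cn1)c1ccc(Cl)cc1` in this assay reaches 93%, the only measured number among the two, the other entry resting at the limit of < 30% in this assay, at which 1 of the 2 values shown sits. Compound 3 `CC(C)[C@H](C(=O)Nc1ccon1)c1ccc(Cl)cc1` differs from compound 2 in one place: 1,2-oxazol-3-yl in place of 5-fluoropyridin-2-yl on an amide-type nitrogen. Within the data shown here, no measured step of this kind exists, so only a modest loss, expected to sit near the edge of the scatter, is anticipated, a number 13 percentage points lower from compound 2 to compound 3 (beyond the scatter). Compound 3 is therefore estimated at 80%, within 45% to 105%.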

Compound 3, largest response reached (reported as efficacy), in percent of the reference or control that the assay uses: 90%
Beside the measured number, compound 3's estimate is 10 percentage points below it; the measured number falls inside the stated range.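

Replacing 5-fluoropyridin-2-yl with 1,2-oxazol-3-yl on the amide-type nitrogen gives a number 3 percentage points lower from compound 2 to compound 3 (within the scatter), the first step shown at this position. In this assay, compound 2 and compound 3 therefore cannot be told apart, even though a six-membered aromatic ring has given way to a five-membered one with a different set of hetero atoms. Nothing shown gives a measured property that bears on this result.

Still open, going by these compounds, is how a non-aromatic group on this nitrogen, such as a longer alkyl chain, or a ring carrying a carboxylic acid, would behave in this assay. A largest response also leaves open how much of each compound is needed to reach it.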